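The source may report more compounds than this note shows. Statements on the series, on what has been measured and on what is new or still open speak of the compounds shown alone.

Compound 2 `Cc1ccc2c(NCc3ccc(NC(=O)C4CCN(Cc5ccccc5F)CC4)cc3)nc(N(C)C)nc2c1` is one of three compounds assessed in a functional assay on SV5A8 cells (Homo sapiens) for cytotoxicity; a higher number here means a weaker inhibitor, a lower number a stronger inhibitor. In this assay compound 2 gives > 6670 nM, which is a limit of the assay and not a number, and so it stands at the limit of > 6670 nM in this assay, at which 1 of the 3 values shown sits. Compound 1 `Cc1ccc2c(NCc3ccc(NC(=O)C4CCN(Cc5ccco5)CC4)cc3)nc(N(C)C)nc2c1` gives > 20000 nM in this assay, likewise a limit. Compound 3 `Cc1ccc2c(NCc3ccc(NC(=O)C4CCN(Cc5ccccc5)CC4)cc3)nc(N3CCN(C)CC3)nc2c1` gives > 17700 nM in this assay, also a limit. With all three values being limits, compound 2 can be placed neither above nor below the other two.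

Compound 4 `CCCCN1CCC(C(=O)Nc2ccc(CNc3nc(N(C)C)nc4cc(C)ccc34)cc2)CC1` has not been measured. It differs from compound 2 by propyl in place of 2-fluorophenyl on a saturated chain carbon bound to an amine nitrogen in a ring. Within the data shown here, the only measured step at the same place, a step that the two limits leave unreadable from compound 1 to compound 2, was left unreadable by its two limits, so no measured step gives a readable size or direction for this change. On that basis the expectation is that compound 4 will most likely again reach only a limit, with an expected step that the limit leaves unreadable from compound 2 to compound 4. Compound 4 is estimated at 15000 nM, with a range from 5000 nM to 45000 nM.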

Compound 4, half-maximal inhibitory concentration: > 10500 nM
Compound 4 gave a limit, no number (the forecaster's own chance of this, stated with the estimate: 80%); the middle value is on the limit's open side.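

In this assay compound 4 gives > 10500 nM, a limit of the assay and not a number. The steps from compound 1 and compound 2 to compound 4 join only limits and cannot be read. The compounds shown leave open whether propyl in place of 2-fluorophenyl changes the half-maximal inhibitory concentration at all.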